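Changing the Aryl Group on a Shared Core

The compounds below may be only part of what the source reports. "The series", "measured", "known", "first", "only" and "open" are said of these compounds alone.

Of the compounds shown here, two built on a shared core have been measured so far. In a functional assay on QG-56 cells (Homo sapiens) for cytotoxicity, read by MTT assay, with a stated time of 48 h (on this read-out lower numbers stand for stronger inhibition and higher numbers for weaker inhibition), compound 1 `COc1cc(/C=C/C(=O)C2=C(/C=C/c3ccc(O)c(OC)c3)NC(=O)NC2c2ccccc2O)ccc1O` gives 100000 nM. Compound 2 `COc1cc(/C=C/C(=O)C2=C(/C=C/c3ccc(O)c(OC)c3)NC(=O)NC2c2c(Cl)cccc2Cl)ccc1O`, with 2,6-dichlorophenyl in place of 2-hydroxyphenyl on a saturated ring carbon, gives 100000 nM, level with compound 1. Among the compounds with values here, the only measured step is no change at the digits printed from compound 1 to compound 2 (within the scatter), and it changes the group at the same place as the next compound.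

That next compound is compound 3 `COc1cc(/C=C/C(=O)C2=C(/C=C/c3ccc(O)c(OC)c3)NC(=O)NC2c2cccc([N+](=O)[O-])c2)ccc1O`, which has 3-nitrophenyl in place of 2,6-dichlorophenyl on the saturated ring carbon: 3-nitrophenyl in place of 2,6-dichlorophenyl on a saturated ring carbon. Within the data shown here, only one earlier step bears on this change, and neither measured compound carries 3-nitrophenyl, so the evidence is thin. The measured step of no change at the digits printed from compound 1 to compound 2 (within the scatter) showed no movement, so no step beyond the scatter is expected in this assay, and no direction can be favoured. The expected step is no change at the digits printed from compound 2 to compound 3 (within the scatter). Compound 3 is estimated at 100000 nM, with an expected range of 40000 nM to 130000 nM.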

Compound 3, half-maximal inhibitory concentration: 25000 nM
Compound 3: the middle estimate sits 4.0-fold (0.60 log units) above what was measured; measured number outside the range, below it.
By their numbers in this assay, from the lowest: compound 3; then compounds 1 and 2 (each within the scatter of the next).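

In this assay, the group on the saturated ring carbon can move the number after all: 3-nitrophenyl in place of 2,6-dichlorophenyl gives a 4.0-fold lower number from compound 2 to compound 3 (0.60 log units; beyond the scatter), and 3-nitrophenyl in place of 2-hydroxyphenyl gives a 4.0-fold lower number from compound 1 to compound 3 (0.60 log units; beyond the scatter). The first pair alone gave no sign that this position responds to a change of aryl group, whereas compound 3 now stands apart from both earlier compounds, by a modest step and in the direction of stronger inhibition. Nothing shown here explains why this group behaves differently from the other two, so the observation remains a bare difference in numbers.

The compounds shown do not separate the contribution of the nitro group from that of the phenyl ring carrying it, and a plain phenyl, or a phenyl bearing an amine or a carboxylic acid instead of the nitro group, would help to test this. Going by these compounds, it also remains open whether the same swap would lower the number in other cell lines, since all three compounds are compared here in a single cytotoxicity test.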